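The source may hold more compounds than are shown below. What is called first, only, known or untested is meant among the compounds shown, and "the series" means these compounds.

In an ADME assay on CCD-1095SK cells (Homo sapiens) for antiproliferative activity, read by crystal violet staining, with a stated time of 96 h (on this read-out higher numbers stand for an effect only at larger amounts of compound and lower numbers for an effect already at smaller amounts), the measured compounds stand as follows: compound 1 `CO[C@H]1[C@H](Oc2ccc3ccccc3c2)OC[C@@H](O)[C@@H]1O` gives 55 uM, compound 2 `O[C@@H]1[C@@H](F)[C@H](Oc2ccc3ccccc3c2)OC[C@H]1O` gives 12 uM, and compound 3 `O[C@H]1[C@H](Oc2ccc3ccccc3c2)OC[C@@H](O)[C@@H]1F` gives 72 uM.

Compound 1 differs from compound 2 by methoxy in place of fluoro on a saturated ring carbon, a change that gave a 4.6-fold higher number from compound 2 to compound 1 (0.66 log units; beyond the scatter). Compound 4 `CO[C@@H]1[C@@H](O)[C@H](Oc2ccc3ccccc3c2)OC[C@H]1O` differs from compound 3 by methoxy in place of fluoro on a saturated ring carbon. The difference between the cores of compound 3 and compound 2 is not broken down here. The two changes are the same kind of change, not the same: in compound 2 the carbon is next to the ring atom that bears a hydroxy group and next to the ring atom that bears a large group, two ring bonds from the ring oxygen, whereas in compound 3 it is next to two ring atoms that each bear a hydroxy group, two ring bonds from the ring atom that bears a large group and three ring bonds from the ring oxygen. Because the earlier step was a 4.6-fold higher number from compound 2 to compound 1 (0.66 log units; beyond the scatter), a similar step of a 1.8-fold higher number from compound 3 to compound 4 (0.26 log units; within the scatter) is expected, though compound 3 already gives the highest number. Compound 4 is estimated at 130 uM in this assay, between 45 uM and 350 uM.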

Compound 4, concentration for half-maximal effect: 17 uM
Compound 4: the middle estimate sits 7.6-fold (0.88 log units) above what was measured, and the stated range ends above it.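

In this assay, methoxy in place of fluoro on a saturated ring carbon gave a 4.2-fold lower number from compound 3 to compound 4 (0.63 log units; beyond the scatter). The change therefore did not carry over from one core to the other, and its direction reversed: the same change on two cores in this assay, a 4.6-fold higher number (0.66 log units; beyond the scatter) from compound 2 to compound 1 and a 4.2-fold lower number (0.63 log units; beyond the scatter) from compound 3 to compound 4, 19-fold (1.29 log units) apart, beyond the scatter of two such steps. This does not show why the two cores part ways, and two pairs give no rule for a further core, only a warning that a step read on one core cannot be assumed on another.

The compounds shown leave open whether an amine or an ethoxy group on these ring carbons would follow the step seen from compound 2 or the one seen from compound 3. As far as these compounds go, whether the two steps keep their opposite directions in other cells also remains open.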